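The source may report more compounds than this note shows. Statements on the series, on what has been measured and on what is new or still open speak of the compounds shown alone.

Compound 2 `CN(C)CCn1cnnc1-c1cc(Oc2ccc(NC(=O)N/N=C/c3ccc(F)cc3Cl)cc2F)ccn1` stands highest of the two numbers given here: in a functional assay on U-87MG ATCC cells (Homo sapiens) for cytotoxicity, read by MTT assay, with a stated time of 72 h (on this read-out higher numbers stand for weaker inhibition and lower numbers for stronger inhibition), compound 2 gives 1210 nM. Compound 1 `CN(C)CCn1cnnc1-c1cc(Oc2ccc(NC(=O)N/N=C/c3cccc(Br)c3)cc2F)ccn1` gives 830 nM, and the step of a 1.5-fold higher number from compound 1 to compound 2 (0.16 log units; within the scatter) lies within the scatter. Compound 3 `CN(C)CCn1cnnc1-c1cc(Oc2ccc(NC(=O)N/N=C/c3cc(Br)c(O)c(Br)c3)cc2F)ccn1` gives only a limit of the assay, > 100000 nM. The steps of an at least 120-fold higher number from compound 1 to compound 3 (2.08 log units; beyond the scatter) and an at least 82-fold higher number from compound 2 to compound 3 (1.91 log units; beyond the scatter) were large, ending at the limit of > 100000 nM in this assay, at which 1 of the 3 values shown sits.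

Compound 4 `COc1ccc(/C=N/NC(=O)Nc2ccc(Oc3ccnc(-c4nncn4CCN(C)C)c3)c(F)c2)c(OC)c1OC` differs from compound 2 by 2,3,4-trimethoxyphenyl in place of 2-chloro-4-fluorophenyl on a carbon with a double bond to nitrogen. Among the measured compounds shown here, no measured step brings in this group: the two large steps both end at compound 3, whereas the swap between the two halogenated rings stayed within the scatter. Compound 4 is therefore expected to sit close to compound 2, with the step of a 1.2-fold higher number from compound 2 to compound 4 (0.09 log units; within the scatter) expected to be small. Compound 4 is estimated at 1500 nM, between 500 nM and 5000 nM.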

Compound 4, half-maximal inhibitory concentration: 7650 nM
For compound 4 the middle estimate is 5.1-fold (0.71 log units) below the measured one; the whole stated range lies below it.
By their numbers in this assay, from the lowest: compounds 1 and 2 (each within the scatter of the next); then compound 4. At a limit, above all of these: compound 3.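

Putting 2,3,4-trimethoxyphenyl on the carbon with a double bond to nitrogen clearly moves the number, with a 6.3-fold higher number from compound 2 to compound 4 (0.80 log units; beyond the scatter) and a 9.2-fold higher number from compound 1 to compound 4 (0.96 log units; beyond the scatter), whereas the swap between the two halogenated rings did not. This position therefore also shows modest steps, not only the large ones that end at compound 3. Compound 3 remains a limit of the assay, so an at least 13-fold lower number from compound 3 to compound 4 (1.11 log units; beyond the scatter) gives only a bound: the limit of > 100000 nM in this assay, at which 1 of the 4 values shown sits.

On these data alone, whether all three methoxy groups are needed for this change remains open. So does what a ring carrying a single methoxy group, an amine or a carboxylic acid would give.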